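A few compounds are considered here, and "the series" means these few. Any claim that something is new, unique, unknown or untested is made for them only; others in the source may bear on it.

Going by the values given here, compound 3 `CC1=CC[C@@H]([C@@](C)(O)CCCC(C)(C)NC(=S)N/N=C\c2ccccc2[N+](=O)[O-])CC1` gives the highest of the three numbers so far in a functional assay on PCO3 cells (Homo sapiens) for cytotoxicity, read by sulforhodamine B assay (a lower number here means a stronger inhibitor of growth, a higher number a weaker inhibitor of growth), at 39900 nM. Compound 1 `CC1=CC[C@@H]([C@@](C)(O)CCCC(C)(C)NC(=S)N/N=C\c2ccc(C)cc2)CC1` gives 6750 nM and compound 2 `CC1=CC[C@@H]([C@@](C)(O)CCCC(C)(C)NC(=S)N/N=C\c2ccc(O)cc2)CC1` gives 6230 nM; a 1.1-fold lower number from compound 1 to compound 2 (0.03 log units; within the scatter). The two steps onto the 2-nitrophenyl ring, a 5.9-fold higher number from compound 1 to compound 3 (0.77 log units; beyond the scatter) and a 6.4-fold higher number from compound 2 to compound 3 (0.81 log units; beyond the scatter), are the only ones beyond the scatter in the series. Compound 4 `CC1=CC[C@@H]([C@@](C)(O)CCCC(C)(C)NC(=S)N/N=C\c2ccccc2Cl)CC1` differs from compound 3 by chloro in place of nitro on an aromatic carbon. Among the compounds with values here, no measured step exchanges one group for another on the same aromatic carbon, so the two steps into compound 3 bear on this change only indirectly: both were modest losses, and part of that loss may be given back once the nitro leaves. The expectation for compound 4 is therefore a step of a 2.7-fold lower number from compound 3 to compound 4 (0.42 log units; beyond the scatter), to about 15000 nM with a range from 5000 nM to 45000 nM.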

Compound 4, concentration for 50% growth inhibition: 18800 nM
Estimate against measurement, compound 4: 1.3-fold (0.10 log units) below, within the range that was stated.
By their numbers in this assay, from the lowest: compounds 2 and 1 (each within the scatter of the next); then compound 4; then compound 3.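

Chloro in place of nitro on this aromatic carbon, ortho to a large group, recovers part of the loss seen with the 2-nitrophenyl ring (a 2.1-fold lower number from compound 3 to compound 4 (0.33 log units; beyond the scatter)). Recovery is incomplete in this assay, as the 2-chlorophenyl ring still stands beyond the scatter from the 4-methylphenyl ring (a 2.8-fold higher number from compound 1 to compound 4 (0.44 log units; beyond the scatter)) and the 4-hydroxyphenyl ring (a 3.0-fold higher number from compound 2 to compound 4 (0.48 log units; beyond the scatter)). Nothing measured here explains this order. As far as these compounds go, whether a methoxy group or an amine on the same aromatic carbon would close the remaining gap stays open. So does the effect of moving chloro to give a 4-chlorophenyl ring.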